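A Chloro Group Enters the Phenol Ring of Compound 1

The source may report more compounds than this note shows. Statements on the series, on what has been measured and on what is new or still open speak of the compounds shown alone.

Three compounds sharing one core have been examined in a physicochemical assay for acid dissociation, using potentiometric titration. Compound 1 `CCC/N=C1\S/C(=C\c2ccc(O)cc2)C(=O)N1c1ccccc1C` gives 8.3 in this assay. Compound 3 `CCC/N=C1\S/C(=C\c2ccc(O)c(C)c2)C(=O)N1c1ccccc1C` gives 8.5, and the step of a number 0.20 log units higher from compound 1 to compound 3 (within the scatter) leaves the two compounds indistinguishable within the scatter. Compound 2 `CCC/N=C1\S/C(=C\c2ccc(O)c(C(F)(F)F)c2)C(=O)N1c1ccccc1C` gives 6.6, and the step of a number 1.70 log units lower from compound 1 to compound 2 (beyond the scatter) puts it clearly below compound 1; the step of a number 1.90 log units higher from compound 2 to compound 3 (beyond the scatter) is of similar size. Compound 1 therefore stands with compound 3 at the upper end of the three, with compound 2 well below.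

Compound 4 `CCC/N=C1\S/C(=C\c2ccc(O)c(Cl)c2)C(=O)N1c1ccccc1C` differs from compound 1 by chloro in place of hydrogen on an aromatic carbon. The two measured steps at this position bear directly on it: the hydrogen-to-methyl step was within the scatter, while the hydrogen-to-trifluoromethyl step was large and downward. A chloro group at the same place is expected to give a downward step beyond the scatter, a number 1.10 log units lower from compound 1 to compound 4 (beyond the scatter), smaller than the step seen for compound 2 because that step was a number 1.70 log units lower from compound 1 to compound 2 (beyond the scatter). Compound 4 is therefore estimated at 7.2, within a range from 6.7 to 7.7.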

Compound 4, acid dissociation constant: 6.8
Compound 4: the middle estimate sits 0.40 log units above what was measured, within the range that was stated.
By their numbers in this assay, from the lowest: compounds 2 and 4 (each within the scatter of the next); then compounds 1 and 3 (each within the scatter of the next).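

At this position, ortho to a hydroxy group, the large downward step is not confined to trifluoromethyl: chloro in place of hydrogen also gives one in this assay (a number 1.50 log units lower from compound 1 to compound 4 (beyond the scatter)). Chloro and trifluoromethyl cannot be told apart here (a number 0.20 log units higher from compound 2 to compound 4 (within the scatter)), so the larger group of the two brings no further measurable change. Chloro in place of methyl gives a large step (a number 1.70 log units lower from compound 3 to compound 4 (beyond the scatter)), which divides the four compounds into two clear pairs, with compounds 1 and 3 at the upper end and compounds 2 and 4 at the lower end.

Going by these compounds, whether a nitrile or an amine at this same place would join the upper or the lower pair remains open. Nothing available explains why the four compounds divide in this way.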